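Adding methylamino to the chain of compound 2

The source may report more compounds than this note shows. Statements on the series, on what has been measured and on what is new or still open speak of the compounds shown alone.

Compound 1 `CC(C)(C)c1cc(C(=O)Nc2nc(CNS(C)(=O)=O)cs2)n(Cc2ccccc2)n1`: 3.1 ug/mL
Compound 2 `Cc1csc(NC(=O)c2cc(C(C)(C)C)nn2Cc2ccccc2)n1`: < 1.6 ug/mL (a limit)

In a physicochemical assay for solubility, read by nephelometry, measured as kinetic solubility, at pH 2.0 (on this read-out higher numbers stand for higher solubility and lower numbers for lower solubility), compound 2 gives only a limit, < 1.6 ug/mL, and no exact number. Compound 3 `CNCc1csc(NC(=O)c2cc(C(C)(C)C)nn2Cc2ccccc2)n1` changes it in one place, with methyl becoming (methylamino)methyl: methylamino in place of hydrogen on a saturated chain carbon bound to an aromatic carbon. Going by the values given here, one measured step bears on this, as it also swaps a group on that chain carbon for hydrogen: an at least 1.9-fold lower number from compound 1 to compound 2 (0.28 log units; that floor lies within the scatter). Its size is only a floor, set by the limit of < 1.6 ug/mL in this assay, at which 1 of the 2 values shown sits. Read in reverse, that step weakly suggests a rise, although methanesulfonamido and methylamino are different groups. The expected change in this assay is an upward one, an at least 7.5-fold higher number from compound 2 to compound 3 (0.87 log units; beyond the scatter). Compound 3 is estimated at 12 ug/mL, with an expected range of 3 ug/mL to 60 ug/mL.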

Compound 3, solubility: 25 ug/mL
Compound 3: the middle estimate sits 2.1-fold (0.32 log units) below what was measured; measured number inside the range.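

In this assay, methylamino on this chain carbon gives an at least 15-fold higher number from compound 2 to compound 3 (1.19 log units; beyond the scatter), so a small change at this position can move the number well beyond the scatter. Compound 2 gives only a limit, so that step is a floor: the limit of < 1.6 ug/mL in this assay, at which 1 of the 3 values shown sits. The substituent on the amine nitrogen also counts, as methyl in place of methylsulfonyl gives an 8.1-fold higher number from compound 1 to compound 3 (0.91 log units; beyond the scatter). Still open, on these data alone, is whether a primary amine, dimethylamino or a carboxylic acid on this carbon would give a similar number. As far as these compounds go, a longer chain between the amine and the aromatic carbon is equally open.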